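Swapping the sulfonyl aryl group in a hydrazide series

A few compounds are considered here, and "the series" means these few. Any claim that something is new, unique, unknown or untested is made for them only; others in the source may bear on it.

Compound 1 `CC(=O)Nc1ccc(S(=O)(=O)NNC(=O)c2cccnc2Nc2ccc(Cl)cc2)cc1` carries a 4-acetamidophenyl group on its sulfonyl sulfur. In a functional assay on SK-MEL-5 cells (Homo sapiens) for antiproliferative activity (a lower number here means a stronger inhibitor of growth, a higher number a weaker inhibitor of growth), compound 1 gives only a limit, > 100000 nM, which marks the edge of what the assay reports and is not a number. Compound 1 thus sits at the limit of > 100000 nM in this assay, at which 1 of the 2 values shown sits. Going by the values given here, compound 2 `O=C(NNS(=O)(=O)c1ccc(F)cc1)c1cccnc1Nc1ccc(Cl)cc1Cl` differs from compound 1 in more than one place, so no single step can be drawn between them. In this assay compound 2 gives 85100 nM. Compound 3 `O=C(NNS(=O)(=O)c1ccc(Cl)cc1Cl)c1cccnc1Nc1ccc(Cl)cc1` has not yet been measured. Its change from compound 1 is 2,4-dichlorophenyl in place of 4-acetamidophenyl on a sulfonyl sulfur. Among the compounds with values here, no measured pair shows this change, so only a guarded expectation is possible. Compound 3 is expected to come in near 60000 nM, within 20000 nM to 100000 nM. The expected step of an at least 1.6-fold lower number from compound 1 to compound 3 (0.22 log units; that floor lies within the scatter) is modest and towards stronger growth inhibition, though a limit again remains possible.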

Compound 3, concentration for total growth inhibition: 29500 nM
For compound 3 the middle estimate is 2.0-fold (0.31 log units) above the measured one; measured number inside the range.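

The aryl group on this sulfonyl sulfur turns out to matter: in this assay, replacing 4-acetamidophenyl with 2,4-dichlorophenyl gives an at least 3.3-fold lower number from compound 1 to compound 3 (0.53 log units; beyond the scatter). With this one change, the series moves off the edge of the assay, and compound 3 gives a true number, 29500 nM. The size of the step remains a floor, because the value for compound 1 is a limit and not a number: the limit of > 100000 nM in this assay, at which 1 of the 3 values shown sits.

What the step cannot separate is the effect of losing the 4-acetamidophenyl group from the effect of gaining the 2,4-dichlorophenyl group, since both happen at once. Also open, on these data alone, is how a plain phenyl ring, or a phenyl ring carrying an amine, would behave on the same sulfonyl sulfur.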